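Swapping isopropyl for cyclopropyl on compound 2

The source may hold more compounds than are shown below. What is called first, only, known or untested is meant among the compounds shown, and "the series" means these compounds.

Measured so far:
- compound 1 `COc1cccc(NC(=O)c2nnn(Cc3ccncc3)c2N)c1` gives 0.7 mL.min-1.g-1
- compound 2 `COc1cccc(NC(=O)c2nnn(Cc3ccc(C(C)C)cc3)c2N)c1` gives 3.2 mL.min-1.g-1
- compound 3 `COc1cccc(NC(=O)c2nnn(CC3CCN(C(=O)OC(C)(C)C)CC3)c2N)c1` gives 10 mL.min-1.g-1

These numbers come from an ADME assay on microsomes from liver (Mus musculus, strain CD1) for metabolic stability, read by HPLC, using NADPH, with a stated time of 30 min; a lower number here means slower removal, a higher number faster removal of the compound. Compound 2 holds the middle place of the three, with compound 3 higher and compound 1 lower.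

The next compound is compound 4 `COc1cccc(NC(=O)c2nnn(Cc3ccc(C4CC4)cc3)c2N)c1`, which differs from compound 2 in one group: cyclopropyl in place of isopropyl on an aromatic carbon. Cyclopropyl stands in place of isopropyl on an aromatic carbon, para to a large group.

Going by the values given here, no measured step makes this exchange. The closest is a 4.6-fold higher number from compound 1 to compound 2 (0.66 log units; beyond the scatter), where 4-isopropylphenyl replaced pyridin-4-yl. That step, beyond the scatter, changed the ring itself and gives only loose guidance. The exchange in compound 4 keeps that ring, so no step beyond the scatter is expected in this assay, and any drift is expected to be slightly downward.

The expected change is a 1.2-fold lower number from compound 2 to compound 4 (0.09 log units; within the scatter).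

Compound 4 is estimated at 2.6 mL.min-1.g-1, with an expected range from 1.2 mL.min-1.g-1 to 5.5 mL.min-1.g-1.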

Compound 4, intrinsic clearance in microsomes: 4.9 mL.min-1.g-1
Compound 4: the middle estimate sits 1.9-fold (0.28 log units) below what was measured; low and high end bracket the measured number.
By their numbers in this assay, from the lowest: compound 1; then compounds 2 and 4 (each within the scatter of the next); then compound 3.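

In this assay, cyclopropyl in place of isopropyl on an aromatic carbon, para to a large group, gives a 1.5-fold higher number from compound 2 to compound 4 (0.19 log units; within the scatter) and so leaves the two compounds indistinguishable, even though the entering group brings a three-membered ring. The earlier step of a 4.6-fold higher number from compound 1 to compound 2 (0.66 log units; beyond the scatter) now has a close partner, since 4-cyclopropylphenyl in place of pyridin-4-yl gives a 7.0-fold higher number from compound 1 to compound 4 (0.85 log units; beyond the scatter) and both of these steps lie beyond the scatter. No measurement at hand explains how either group acts on the number.

Still open, as far as these compounds go, is whether an amine, a carboxylic acid or a longer chain at this same place would also stay within the scatter of compound 2. It is equally unknown whether swapping isopropyl for cyclopropyl would give so small a step elsewhere on the shared core.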